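Swapping an Acid-Bearing Side Chain for a Basic Amine

The source may report more compounds than this note shows. Statements on the series, on what has been measured and on what is new or still open speak of the compounds shown alone.

Compound 2 `CCCCCCCCCCCC(=O)OC[C@H](CSC[C@@H](N)C(=O)N[C@@H](CC)COCC(=O)O)OC(=O)CCCCCCCCCCC` is a lipopeptide-like molecule in which a doubly acylated glycerol is linked through a thioether to a cysteine-derived amide. Among the compounds with values here, in an assay on HEK293 cells for agonist activity at Toll-like receptor 2 (Homo sapiens) (on this read-out lower numbers stand for an effect already at smaller amounts and higher numbers for an effect only at larger amounts of compound), compound 2 gives 6500 nM, the highest of the two numbers measured so far. Within the data shown here, its only measured neighbour, compound 1 `CCCCCCCCCCCC(=O)OC[C@H](CSC[C@@H](N)C(=O)NCCO)OC(=O)CCCCCCCCCCC`, gives 24 nM in this assay. Among the measured compounds shown here, the single measured step, a 270-fold higher number from compound 1 to compound 2 (2.43 log units; beyond the scatter), shows that enlarging the group on the amide-type nitrogen from 2-hydroxyethyl to 1-((carboxymethoxy)methyl)propyl costs a great deal of potency.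

Compound 3 `CCCCCCCCCCCC(=O)OC[C@H](CSC[C@@H](N)C(=O)NC(C)CCN(CC)CC)OC(=O)CCCCCCCCCCC` changes the same position again: 3-(diethylamino)-1-methylpropyl in place of 1-((carboxymethoxy)methyl)propyl on an amide-type nitrogen. For the measured compounds named here, no measured pair probes this particular exchange, so the only guidance is that this position is sensitive and that compound 1, with a small neutral group there, sits far lower. A step of an 8.1-fold lower number from compound 2 to compound 3 (0.91 log units; beyond the scatter) in this assay is therefore expected for compound 3, a partial return rather than a full recovery, with wide uncertainty. The estimate for compound 3 in this assay is 800 nM, with a likely range from 80 nM to 8000 nM.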

Compound 3, half-maximal effective concentration: 257 nM
The estimate for compound 3 lay 3.1-fold (0.49 log units) above the measured number; the measured number falls inside the stated range.
By their numbers in this assay, from the lowest: compound 1; then compound 3; then compound 2.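

The position tolerates more than the first two compounds suggested: a 25-fold lower number from compound 2 to compound 3 (1.40 log units; beyond the scatter) in this assay shows that a large group here need not cost as much as the 1-((carboxymethoxy)methyl)propyl group did. Both groups hold 9 heavy atoms, so that count alone does not set the number, and what differs is their makeup, with a diethylamino end and only carbon and nitrogen in the entering group against three oxygens in the group that leaves. Even so, the small 2-hydroxyethyl group stays ahead, as an 11-fold higher number from compound 1 to compound 3 (1.03 log units; beyond the scatter) shows, and nothing measured here explains why these groups differ.

On these data alone, what remains open is whether chain length or the group at the chain end matters more, and a 2-aminoethyl or a 3-hydroxypropyl group on the amide-type nitrogen would help to separate the two. The role of the methyl branch in the 3-(diethylamino)-1-methylpropyl group is also unsettled, and a straight 3-(diethylamino)propyl chain would test it directly.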